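The compounds below may be only part of what the source reports. "The series", "measured", "known", "first", "only" and "open" are said of these compounds alone.

Compound 1 `CCCCN(CC)c1cc(C)nc2c1NC(=O)CN2c1ccc(C)cc1Br` is examined in an assay on HEK-293T cells for displacement of a labelled ligand from corticotropin-releasing factor receptor 2 (Homo sapiens), read by scintillation counting, with a stated time of 2 h, tested at 1 uM (a lower number here means less inhibition, a higher number more inhibition at the concentration tested (going by the name of the read-out)), where compound 1 gives 5.5%. Compound 2 `CCCCN(CC)c1cc(C)nc2c1NC(=O)CN2c1ccc(Br)cc1C` gives 5.9% in this assay, while for compound 3 `CCCCN(CC)c1cc(C)nc2c1NC(=O)CN2c1ccc(Cl)cc1C` the result is "not determined" (no result reported). Compound 1 thus stands lowest of the two numbers available, with compound 2 nearest, although the step was a number 0.4 percentage points higher from compound 1 to compound 2 (within the scatter). The change to compound 4 `CCCCN(CC)c1cc(C)nc2c1NC(=O)CN2c1ccc(Br)cc1CC` is 4-bromo-2-ethylphenyl in place of 2-bromo-4-methylphenyl on a nitrogen on an aromatic ring in a ring. For the measured compounds named here, the only measured step that bears on it, also an exchange of the whole aryl group on that nitrogen, was a number 0.4 percentage points higher from compound 1 to compound 2 (within the scatter). Because compound 2 gives 5.9% with a closely related aryl group, the expected step is a number 0.5 percentage points higher from compound 1 to compound 4 (within the scatter), none beyond the scatter. Compound 4 is therefore estimated at 6%, within 0% to 18%.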

Compound 4, a percentage reported as inhibition, at one concentration (the size of the read-out at that concentration, not a potency): 2.1%
Compound 4: middle estimate off by 3.9 percentage points, on the high side, within the range that was stated.
By their numbers in this assay, from the lowest: compounds 4, 1 and 2 (each within the scatter of the next).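

Within this assay, methyl in place of hydrogen on the saturated chain carbon bound to an aromatic carbon gives a number 3.8 percentage points lower from compound 2 to compound 4 (within the scatter) and so does not move the number past the usual scatter. Exchanging 2-bromo-4-methylphenyl for 4-bromo-2-ethylphenyl gives a number 3.4 percentage points lower from compound 1 to compound 4 (within the scatter) and likewise stays within it, so neither change separates these compounds. No evidence is available on the cause of these results. From the compounds shown here alone, whether a propyl chain at this place, or an amine or a carboxylic acid on the aryl group, would give a step beyond the scatter remains open.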